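Removing a Chloro Group in Two Amide Series

The source may report more compounds than this note shows. Statements on the series, on what has been measured and on what is new or still open speak of the compounds shown alone.

Measured in an assay for inhibition of HSP60/HSP10 (Homo sapiens), with a stated time of 60 min (on this read-out higher numbers stand for weaker inhibition and lower numbers for stronger inhibition), where every value recorded is a limit of the assay and not a number:
compound 1, `COc1ccccc1C(=O)Nc1cccc(Cl)c1`: > 100000 nM
compound 2, `COc1ccccc1C(=O)Nc1ccccc1`: > 100000 nM
compound 3, `O=C(Nc1cccc(Cl)c1)c1cccc(Br)c1O`: > 100000 nM

Compound 1 and compound 2 share one core and differ by hydrogen in place of chloro on an aromatic carbon. The step from the first to the second in this assay is a step that the two limits leave unreadable from compound 1 to compound 2, so no size can be read for it, since both compounds sit at the limit of > 100000 nM in this assay, at which 3 of the 3 values shown sit. Compound 3 carries a different core; the difference between the two cores is not broken down here.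

Compound 4, `O=C(Nc1ccccc1)c1cccc(Br)c1O`, has not yet been measured in this assay. It stands to compound 3 as compound 2 stands to compound 1: the change is hydrogen in place of chloro on an aromatic carbon, made at the same kind of place. Among the compounds with values here, for the measured pair the step is unreadable, and compound 3 itself sits at the limit of > 100000 nM in this assay, at which 3 of the 3 values shown sit, so there is no measured step on which a size could rest. The account therefore expects the step that the limit leaves unreadable from compound 3 to compound 4 from compound 3 to compound 4 to be small, because all three measured compounds sit at the limit of > 100000 nM in this assay, at which 3 of the 3 values shown sit. On that basis compound 4 is estimated to give 150000 nM in this assay, most likely again reported only as a limit, with a range from 50000 nM to 500000 nM.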

Compound 4, half-maximal inhibitory concentration: > 100000 nM
Compound 4 gave a limit, no number (the forecaster's own chance of this, stated with the estimate: 85%); the middle value does not contradict the limit.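

In this assay, within the data shown here, compound 3 and compound 4 both stay at a limit of the assay and not at a number, so the step between them cannot be read, any more than the one between compound 1 and compound 2: the limit of > 100000 nM in this assay, at which 4 of the 4 values shown sit. The compounds shown leave open how large the change from chloro to hydrogen is in either series, and how the two cores compare.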